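This account rests on a few compounds, and the source may have more. Where it says the series, first, only, none or still open, it means among the compounds named here.

Of the compounds shown here, three from one series have been tested in an ADME assay on HEL cells (Homo sapiens) for cytotoxicity; on this read-out lower numbers stand for higher toxicity in this test and higher numbers for lower toxicity in this test. Compound 1, `[O-]c1on[n+](-c2ccc(Cc3ccc(-[n+]4noc([O-])c4CN4CCNCC4)cc3)cc2)c1CN1CCNCC1`, gives 20 ug/mL in this assay. Compound 2, `Cc1ccc(-[n+]2noc([O-])c2CN2CCN(C)C(c3ccccc3)C2)cc1`, gives 23.7 ug/mL in this assay, the higher of the two numbers, but the gap to compound 1 lies within the usual scatter of repeated measurements, so the two cannot be told apart. Compound 3, `[O-]c1on[n+](-c2ccc(Cc3ccc(-[n+]4noc([O-])c4CN4CCN(c5cccc(Cl)c5)CC4)cc3)cc2)c1CN1CCN(c2cccc(Cl)c2)CC1`, reaches only a limit of the assay, > 100 ug/mL, namely (the limit of > 100 ug/mL in this assay, at which 1 of the 3 values shown sits).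

Compound 4, `Cc1ccc(-[n+]2noc([O-])c2CN2CCN(C)CC2)cc1`, has not yet been measured. It differs from compound 2 in one place: hydrogen in place of phenyl on a saturated ring carbon. Among the compounds with values here, no measured pair in this set isolates that change, so its effect must be judged from compound 2 alone. The step is expected to be modest and, if anything, toward a higher number: a 1.5-fold higher number from compound 2 to compound 4 (0.17 log units; within the scatter). Compound 4 is accordingly estimated at 35 ug/mL in this assay, with a plausible range from 15 ug/mL to 90 ug/mL.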

Compound 4, half-maximal cytotoxic concentration: 25.6 ug/mL
Compound 4: the middle estimate sits 1.4-fold (0.14 log units) above what was measured, within the range that was stated.
By their numbers in this assay, from the lowest: compounds 1, 2 and 4 (each within the scatter of the next). At a limit, above all of these: compound 3.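

In this assay, hydrogen in place of phenyl on a saturated ring carbon gives a 1.1-fold higher number from compound 2 to compound 4 (0.03 log units; within the scatter) and so leaves compound 2 and compound 4 indistinguishable. Within the data shown here, this is the first pair that isolates one change, and it shows that on this core the read-out does not depend on the phenyl at this position: a group of six heavy atoms can go without a difference that this test can resolve. Nothing measured here offers a reason for this outcome.

Going by these compounds, whether this tolerance extends to other groups on the same ring carbon, such as a hydroxyl, a carboxylic acid or a primary amine, remains open. So does whether a chlorophenyl in place of the phenyl would leave the number equally undisturbed.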